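The compounds below may be only part of what the source reports. "The series", "measured", "known", "first", "only" and "open" are said of these compounds alone.

In a functional assay on HepG2 cells (Homo sapiens) for antiproliferative activity, read by MTT assay, with a stated time of 48 h (on this read-out lower numbers stand for stronger inhibition and higher numbers for weaker inhibition), compound 2 `O=C(/C=C/c1c[nH]c2ccccc12)Nc1ccc2ncnc(Nc3cccc(Cl)c3)c2c1` gives 7020 nM. Compound 1 `O=C(/C=C/c1cccs1)Nc1ccc2ncnc(Nc3cccc(Cl)c3)c2c1` gives 10400 nM. Compound 2 thus holds the smaller of the two numbers, though the gap, a 1.5-fold lower number from compound 1 to compound 2 (0.17 log units; within the scatter), lies within the scatter. That single measured step swapped one aromatic group for another at the same place on the chain and changed little. Compound 3 `O=C(/C=C/c1cccnc1Cl)Nc1ccc2ncnc(Nc3cccc(Cl)c3)c2c1` makes a swap of the same kind: 2-chloropyridin-3-yl in place of 1H-indol-3-yl on a double-bonded chain carbon bound to a double-bonded chain carbon. Within the data shown here, with only that one step to go on, the expected change from compound 2 to compound 3 is none beyond the scatter, a 1.1-fold higher number from compound 2 to compound 3 (0.06 log units; within the scatter). Compound 3 is therefore estimated at 8000 nM, within a range from 3000 nM to 20000 nM.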

Compound 3, half-maximal inhibitory concentration: 4420 nM
For compound 3 the middle estimate is 1.8-fold (0.26 log units) above the measured one; low and high end bracket the measured number.
By their numbers in this assay, from the lowest: compounds 3, 2 and 1 (each within the scatter of the next, the first and the last beyond it).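

Among these compounds, changing the aromatic group at this place on the chain can move the number beyond the scatter: 2-chloropyridin-3-yl in place of thiophen-2-yl gives a 2.4-fold lower number from compound 1 to compound 3 (0.37 log units; beyond the scatter) in this assay and is the first such step here. Set against 1H-indol-3-yl, the same group gives only a 1.6-fold lower number from compound 2 to compound 3 (0.20 log units; within the scatter) and so, despite the loss of the hydrogen-bond donor and of one ring, no change can be read. As far as these compounds go, how a non-aromatic group at this place, such as an amine or a carboxylic acid, would compare stays open. Nothing measured here gives a reason for either step.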